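Imidazole substituent variation in a bombesin receptor subtype-3 agonist series

The source may report more compounds than this note shows. Statements on the series, on what has been measured and on what is new or still open speak of the compounds shown alone.

Measured compounds:
- compound 1: `CCCCc1cnc(CCCc2ccc(-c3ccccc3C(=O)O)cc2)[nH]1`, 5600 nM
- compound 2: `O=C(O)c1ccccc1-c1ccc(CCc2ncc(Cc3ccccc3Cl)[nH]2)cc1`, 292 nM

In an in vitro functional assay on cells for agonist activity at Bombesin receptor subtype-3 (Homo sapiens), read by luminescence and calcium flux (on this read-out lower numbers stand for an effect already at smaller amounts and higher numbers for an effect only at larger amounts of compound), compound 2 gives 292 nM, the lower of the two numbers recorded; compound 1 gives 5600 nM, a gap that lies beyond the usual scatter. Within the data shown here, compound 1 carries a butyl group on the five-membered ring where compound 2 carries 2-chlorobenzyl; the two values show that this part of the structure matters for the read-out, though with only two compounds no broader pattern can be claimed.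

Compound 3, `O=C(O)c1ccccc1-c1ccc(CCc2ncc(-c3ccccc3)[nH]2)cc1`, has not yet been measured. It differs from compound 2 in one place: phenyl in place of 2-chlorobenzyl on an aromatic carbon. The aryl group is thus kept but drawn directly onto the aromatic carbon, and the chlorine is gone. Since compound 1 shows that a smaller, non-aryl substituent at this position gives 5600 nM, a step toward weaker activity is expected, of moderate size.

Compound 3 is expected to give 1500 nM, in the range 400 nM to 6000 nM, meaning an estimated step of a 5.1-fold higher number from compound 2 to compound 3 (0.71 log units; beyond the scatter).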

Compound 3, half-maximal effective concentration: 4950 nM
The estimate for compound 3 lay 3.3-fold (0.52 log units) below the measured number; the measured number falls inside the stated range.
By their numbers in this assay, from the lowest: compound 2; then compounds 3 and 1 (each within the scatter of the next).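

In this assay the swap of 2-chlorobenzyl for phenyl on this aromatic carbon gives a 17-fold higher number from compound 2 to compound 3 (1.23 log units; beyond the scatter) and so counts as a large change at this position. Keeping a six-membered aromatic ring here is therefore not enough to retain the lower number of compound 2, a point that the butyl group of compound 1 could not address, and the position responds to more than the presence of an aryl group. No measurement at hand bears on the cause of this step.

From the compounds shown here alone, the change removes the chlorine and the carbon linking the aromatic ring together, so the share of each stays open. Unsubstituted benzyl or 2-chlorophenyl on the same carbon would separate the two contributions.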